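Trimming the amide substituent: oxanyl to methoxy

This account rests on a few compounds, and the source may have more. Where it says the series, first, only, none or still open, it means among the compounds named here.

Measured compounds:
compound 1 `CNC(=O)c1cc(C)n(Cc2cc(Cl)ccc2OCc2ccccc2)n1`: 100 nM
compound 2 `Cc1cc(NC(=O)C2CCOCC2)nn1Cc1cc(Cl)ccc1OCc1ccccc1`: 63.1 nM

In an assay on CHO-K1 cells for displacement of a labelled ligand from prostaglandin E2 receptor EP1 subtype (Homo sapiens) (on this read-out lower numbers stand for stronger inhibition and higher numbers for weaker inhibition), compound 2 gives 63.1 nM, the lowest of the two numbers, and the step of a 1.6-fold lower number from compound 1 to compound 2 (0.20 log units; within the scatter) lies within the scatter. Compound 3 `COC(=O)Nc1cc(C)n(Cc2cc(Cl)ccc2OCc2ccccc2)n1` differs from compound 2 by methoxy in place of oxan-4-yl on a carbonyl carbon. Going by the values given here, the only measured step swaps the whole amide arrangement rather than the group on the carbonyl carbon, so it bears on this change only loosely and no measured step tests it directly. The step from compound 2 to compound 3 is therefore expected to be a 1.6-fold higher number from compound 2 to compound 3 (0.20 log units; within the scatter), nothing beyond the scatter. Compound 3 is estimated at 100 nM, with a range from 30 nM to 320 nM.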

Compound 3, half-maximal inhibitory concentration: 200 nM
The estimate for compound 3 lay 2.0-fold (0.30 log units) below the measured number; low and high end bracket the measured number.
By their numbers in this assay, from the lowest: compounds 2, 1 and 3 (each within the scatter of the next, the first and the last beyond it).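

In this assay, going by these compounds alone, replacing oxan-4-yl on the carbonyl carbon with the smaller methoxy gives a 3.2-fold higher number from compound 2 to compound 3 (0.50 log units; beyond the scatter) and is the first step here beyond the scatter, so the group at this place can affect the number. Replacing methylcarbamoyl with (methoxycarbonyl)amino gives a 2.0-fold higher number from compound 1 to compound 3 (0.30 log units; within the scatter) and stays within the scatter. No evidence is available to explain either step. As far as these compounds go, it remains open whether a cyclohexyl group, which lacks the ring oxygen of oxan-4-yl, would match compound 2 . From the compounds shown here alone, whether an ethoxy group would differ from methoxy also remains open.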